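A methoxy added to the core of compound 3

The source may hold more compounds than are shown below. What is called first, only, known or untested is meant among the compounds shown, and "the series" means these compounds.

In a functional assay on 1A9 cells (Homo sapiens) (a lower number here means that less compound is needed, a higher number that more compound is needed for the effect), compound 3 `COc1cccc(-c2nc(O)c3ccccc3n2)c1` is recorded as "not active" (no number reported) and has no number. Compound 1 `Oc1nc(-c2cccc(F)c2)nc2ccccc12` gives > 20 ug/mL which is a limit and not a number. Compound 2 `COc1cc2nc(-c3ccc4ccccc4c3)nc(O)c2cc1OC` gives 7.8 ug/mL as the only numeric result among the three. The step methoxy in place of hydrogen on an aromatic carbon puts methoxy in place of hydrogen on an aromatic carbon of the fused system. Among the measured compounds shown here, no measured step guides this change, so for compound 4 `COc1cccc(-c2nc(O)c3cc(OC)ccc3n2)c1` only a modest move towards a lower number is expected in this assay and a result still without a number would not surprise. Compound 4 is estimated at 15 ug/mL with an expected range from 5 ug/mL to 40 ug/mL if a number is reported at all.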

Compound 4, concentration for half-maximal effect: 4.7 ug/mL
Compound 4: middle estimate off by 3.2-fold (0.50 log units), on the high side; measured number outside the range, below it.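

Among the compounds shown here, compound 3 has no number in this assay, so no step to compound 4 can be read, although compound 4 gives 4.7 ug/mL. The compounds shown leave open how far compound 3 lies from compound 4, and whether it lies near the limit recorded for compound 1: the limit of > 20 ug/mL in this assay, at which 1 of the 4 values shown sits.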